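This account rests on a few compounds, and the source may have more. Where it says the series, first, only, none or still open, it means among the compounds named here.

Working notes on the series in a functional assay on A549 cells (Homo sapiens) for antiproliferative activity, read by MTT assay, with a stated time of 72 h; a higher number here means a weaker inhibitor, a lower number a stronger inhibitor.

Compound 1 `CN(C(=O)c1ccccc1)c1ccc2[nH]c(-c3n[nH]c4ccccc34)cc2n1` gives 13800 nM. Among the three measured compounds it gives the second highest number: compound 3 `CN(C(=O)c1ccco1)c1ccc2[nH]c(-c3n[nH]c4ccccc34)cc2n1` gives 15500 nM, and the step of a 1.1-fold higher number from compound 1 to compound 3 (0.05 log units; within the scatter) lies within the scatter, so the two are not separated. Compound 2 `CN(C(=O)c1ccc(Br)cc1)c1ccc2[nH]c(-c3n[nH]c4ccccc34)cc2n1` gives 4250 nM, and the step of a 3.2-fold lower number from compound 1 to compound 2 (0.51 log units; beyond the scatter) is beyond the scatter. The step of a 3.6-fold higher number from compound 2 to compound 3 (0.56 log units; beyond the scatter) is of similar size in the other direction.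

Compound 4 `CN(C(=O)c1ccccc1)c1ccc2[nH]c(-c3n[nH]c4cc(Cl)ccc34)cc2n1` is not yet measured. It differs from compound 1 by chloro in place of hydrogen on an aromatic carbon. Among the measured compounds shown here, the only measured step that bears on it is the halogen change from compound 1 to compound 2, which was a 3.2-fold lower number from compound 1 to compound 2 (0.51 log units; beyond the scatter); that halogen, however, sits on the phenyl on the carbonyl carbon, whereas the chloro of compound 4 sits on the shared core. For the measured compounds named here, no measured step touches the core, so the bearing is indirect. A modest lowering of the number, at most of the order seen from compound 1 to compound 2, is therefore expected, with a step that may also fall within the scatter. For compound 4 the expected step is a 1.5-fold lower number from compound 1 to compound 4 (0.19 log units; within the scatter). Compound 4 is estimated at 9000 nM, within 3500 nM to 25000 nM.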

Compound 4, half-maximal inhibitory concentration: 9590 nM
Beside the measured number, compound 4's estimate is 1.1-fold (0.03 log units) below it; measured number inside the range.
By their numbers in this assay, from the lowest: compound 2; then compounds 4, 1 and 3 (each within the scatter of the next).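

Among the compounds shown here, compound 4 gives the first reading of a change on the shared core rather than on the phenyl on the carbonyl carbon: in this assay, chloro in place of hydrogen on an aromatic carbon, meta to a fused ring and para to a fused ring, gives a 1.4-fold lower number from compound 1 to compound 4 (0.16 log units; within the scatter) and so does not separate the two compounds. For the compounds shown here, this position therefore accepts a chloro with no change that can be told from the scatter, whereas the only halogen step beyond the scatter so far, a 3.2-fold lower number from compound 1 to compound 2 (0.51 log units; beyond the scatter), lies on the phenyl on the carbonyl carbon. That bromo step differs from the new step in both the halogen and its place, so the pair gives no general halogen rule, and no measurement in hand explains either result.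

From the compounds shown here alone, whether a larger or different group at this core position, such as bromo, methoxy, an amine or a carboxylic acid, would move the number beyond the scatter remains open. Also open, going by these compounds, is whether the chloro on the core and the bromo on the phenyl would act independently if both stood on one compound.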